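The source may hold more compounds than are shown below. What is called first, only, known or untested is meant among the compounds shown, and "the series" means these compounds.

Compound 1 `Cc1ccccc1NC(=S)N1CCc2c(sc(NC(=O)c3ccccc3Cl)c2C(N)=O)C1` and compound 2 `NC(=O)c1c(NC(=O)c2ccccc2Cl)sc2c1CCN(C(=S)Nc1ccccc1-c1ccccc1)C2` share a common core and differ only in the group carried on the amide-type nitrogen next to the thiocarbonyl carbon. In a functional assay on HL-60 cells (Homo sapiens) for antiproliferative activity, with a stated time of 24 h (a lower number here means a stronger inhibitor, a higher number a weaker inhibitor), compound 1 gives 22600 nM, and in this assay compound 2 gives 34400 nM. For the measured compounds named here, the step of a 1.5-fold higher number from compound 1 to compound 2 (0.18 log units; within the scatter) is the only measured step in this set, and it lies within the scatter. Compound 2 therefore stands with the higher of the two numbers, but not separated from compound 1 by more than the usual spread of repeats.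

Compound 3 `NC(=O)c1c(NC(=O)c2ccccc2Cl)sc2c1CCN(C(=S)Nc1c(Cl)cccc1Cl)C2` is the untested member. Its change from compound 2 is 2,6-dichlorophenyl in place of 2-phenylphenyl on an amide-type nitrogen, so it alters the same position that was altered between compound 1 and compound 2. That single step, a 1.5-fold higher number from compound 1 to compound 2 (0.18 log units; within the scatter), was small, and it shows that exchanging the group on this nitrogen has so far left the readout in this assay essentially unmoved. On that basis compound 3 is expected to show a step of a 1.2-fold lower number from compound 2 to compound 3 (0.09 log units; within the scatter), meaning no change beyond the scatter. The estimate for compound 3 in this assay is 28000 nM, with a range from 11000 nM to 70000 nM.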

Compound 3, half-maximal inhibitory concentration: 3950 nM
Beside the measured number, compound 3's estimate is 7.1-fold (0.85 log units) above it; measured number below the stated range.
By their numbers in this assay, from the lowest: compound 3; then compounds 1 and 2 (each within the scatter of the next).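

The earlier pair left this position looking insensitive, but the group on this amide-type nitrogen can in fact move the number beyond the scatter in this assay: 2,6-dichlorophenyl in place of 2-phenylphenyl gives an 8.7-fold lower number from compound 2 to compound 3 (0.94 log units; beyond the scatter), and 2,6-dichlorophenyl in place of 2-methylphenyl gives a 5.7-fold lower number from compound 1 to compound 3 (0.76 log units; beyond the scatter). Both steps beyond the scatter bring in the same group, whereas the exchange of 2-methylphenyl for 2-phenylphenyl stayed within it, so among these three compounds the lower number appears only with 2,6-dichlorophenyl. No measurement here bears on why this group behaves differently from the other two.

As far as these compounds go, whether the shift belongs to the chlorine atoms or to having two groups on the ring stays open, and a 2-chlorophenyl or a 2,6-dimethylphenyl group on the same nitrogen would separate those readings. From the compounds shown here alone, it is also open whether this nitrogen tolerates a ring bearing an amine or a carboxylic acid, and whether the lower number would persist with the rest of the shared core changed.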